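A limit-bound series and one aryl change

The compounds below may be only part of what the source reports. "The series", "measured", "known", "first", "only" and "open" are said of these compounds alone.

Compound 1 `O=C(NCCNS(=O)(=O)c1ccc(-c2ccccc2Oc2ccc([N+](=O)[O-])c([N+](=O)[O-])c2)s1)Nc1cc(Cl)cc(Cl)c1`: > 20000 nM
Compound 2 `COc1cccc(NC(=O)NCCNS(=O)(=O)c2ccc(-c3ccccc3OCc3ccccc3)s2)c1`: > 50000 nM
Compound 3 `COc1ccc(Oc2ccccc2-c2ccsc2S(=O)(=O)N2CCN(C(=O)Nc3cc(C(F)(F)F)cc(C(F)(F)F)c3)CC2)cc1OC`: > 50000 nM

All three compounds were tested in a functional assay on HeLa cells (Homo sapiens) for inhibition, read by CCK-8 assay, with a stated time of 48 h (on this read-out higher numbers stand for weaker inhibition and lower numbers for stronger inhibition), and none of them gave a number, only a limit. In this assay compound 2 gives > 50000 nM, which is a limit of the assay. Compound 2 thus stands at the limit of > 50000 nM in this assay, at which 2 of the 3 values shown sit. Compound 1 stands at the limit of > 20000 nM in this assay, at which 1 of the 3 values shown sits.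

Compound 4 `Cc1cc(C)cc(NC(=O)NCCNS(=O)(=O)c2ccc(-c3ccccc3OCc3ccccc3)s2)c1` has not yet been measured. It keeps the core of compound 2 and changes in one place, with 3,5-dimethylphenyl in place of 3-methoxyphenyl on an amide-type nitrogen.

Within the data shown here, no measured pair shows a single change, so the expectation rests on compound 2 alone, whose > 50000 nM is a limit. In this assay no step beyond the usual scatter is expected. The estimated change is a number no higher from compound 2 to compound 4 (the limit leaves the size open). A report of only a limit is the likelier outcome. For compound 4 the estimated value is 50000 nM, with an expected range of 15000 nM to 100000 nM.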

Compound 4, half-maximal inhibitory concentration: > 50000 nM
Compound 4: no number, only a limit; the forecaster's own chance of this, stated with the estimate: 70%; the middle value sits exactly at the limit.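

In this assay compound 4 gives > 50000 nM, a limit of the assay. Since compound 2 also gave only a limit, no step can be read between compound 2 and compound 4. The compounds shown leave open whether either aryl group would allow a measurable value in this assay.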